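The compounds below may be only part of what the source reports. "The series", "measured", "known", "first", "only" and "open" are said of these compounds alone.

Measured compounds:
compound 1, `C[C@]1(c2ccccc2)OCC[C@H](CCN)O1` — > 10000 nM (a limit)
compound 2, `C[C@]1(c2ccccc2)OCC[C@H](CCNCc2ccccc2)O1` — 11 nM

Compound 1 `C[C@]1(c2ccccc2)OCC[C@H](CCN)O1` carries a free primary amine. In an assay on brain for displacement of a labelled ligand from Sigma non-opioid intracellular receptor 1 (Cavia porcellus) (a lower number here means a stronger inhibitor, a higher number a weaker inhibitor), compound 1 gives > 10000 nM, which is a limit of the measurement and not a number; it sits at the limit of > 10000 nM in this assay, at which 1 of the 2 values shown sits. Compound 2 `C[C@]1(c2ccccc2)OCC[C@H](CCNCc2ccccc2)O1` has a benzyl group on that amine nitrogen in place of hydrogen, and in this assay compound 2 gives 11 nM. Among the compounds with values here, this is the only numerical value in the set; the other value shown is a limit. Within the data shown here, the step of an at least 900-fold lower number from compound 1 to compound 2 (2.95 log units; beyond the scatter) is the single measured step, and it is large.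

Compound 3 `C[C@@]1(c2ccccc2)OCC[C@@H](CCNCc2ccccc2)O1` is still to be measured. Relative to compound 2 the change is the two compounds have the same atoms and bonds and differ only in configuration as drawn: 2 of 2 stereo elements differ (all stereocentres are inverted: mirror images); a stereocentre at a saturated ring carbon is drawn S in compound 2 and R in compound 3; a stereocentre at a saturated ring carbon is drawn S in compound 2 and R in compound 3. Among the measured compounds shown here, no measured step concerns a change of configuration: the one measured step turned on a benzyl group entering on the amine nitrogen, and so does not bear on the step from compound 2 to compound 3. The expectation therefore rests on compound 2 alone, with a wide range allowed for the inversion of both stereocentres.

For compound 3 the expected value in this assay is 30 nM, within 6 nM to 200 nM, corresponding to an expected step of a 2.7-fold higher number from compound 2 to compound 3 (0.44 log units; beyond the scatter).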

Compound 3, inhibition constant: 17 nM
Compound 3: the middle estimate sits 1.8-fold (0.25 log units) above what was measured; the range from low to high includes it.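

In this assay, inverting both stereocentres gives a 1.5-fold higher number from compound 2 to compound 3 (0.19 log units; within the scatter), so the two mirror images cannot be told apart in this read-out. Within the data shown here, the earlier step showed only that the group on the amine nitrogen matters; this one adds that, with benzyl on that nitrogen, inverting the two saturated ring carbons together does not move the number beyond the scatter. The comparison isolates configuration, with no group entering or leaving: the fact that compounds 2 and 3 differ only in the configuration as drawn.

Inversion of only one of the two stereocentres remains open, and with it whether each centre has no influence of its own or whether two separate influences cancel in the mirror-image pair. Also open, going by these compounds, is whether configuration stays without consequence when methyl or 2-phenylethyl replaces benzyl on the amine nitrogen, when a longer chain carries the amine, or when the amine is primary, where the value of compound 1 is a limit and not a number: the limit of > 10000 nM in this assay, at which 1 of the 3 values shown sits.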